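This account rests on a few compounds, and the source may have more. Where it says the series, first, only, none or still open, it means among the compounds named here.

Compound 1 `CNC(=O)c1cc(Oc2ccc3cc(C(=O)OC(C)C)n(C)c3c2)ccn1` and compound 2 `CNC(=O)c1cc(Oc2ccc3c(C)c(C(=O)OC(C)C)n(C)c3c2)ccn1` share one core, while compound 3 `CCOC(=O)c1cc2ccc(OC)cc2s1` and the as yet unmeasured compound 4 `CCOC(=O)c1sc2cc(OC)ccc2c1C` share another; the difference between the two cores is not broken down here. In an ADME assay on H1-HeLa cells (Homo sapiens) for cytotoxicity, read by MTT assay, with a stated time of 3 days (a higher number here means that more compound is tolerated, a lower number that less compound is tolerated), compound 1 gives 10300 nM, compound 2 gives 11200 nM and compound 3 gives 70900 nM, so the two values of compound 1 and compound 2 lie within the scatter of each other, and compound 3 stands well apart from both.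

The change from compound 1 to compound 2 is methyl in place of hydrogen on an aromatic carbon. It produced a 1.1-fold higher number from compound 1 to compound 2 (0.04 log units; within the scatter). The same kind of change is now made from compound 3 to compound 4: methyl in place of hydrogen on an aromatic carbon. The surroundings are not identical, since in compound 1 the place is two ring bonds from the ring nitrogen and from the ring atom that bears a methyl group, whereas in compound 3 it is two ring bonds from the ring sulfur.

Because a 1.1-fold higher number from compound 1 to compound 2 (0.04 log units; within the scatter) was within the scatter, the step for compound 4 is expected to be a 1.1-fold higher number from compound 3 to compound 4 (0.02 log units; within the scatter). Compound 4 is therefore estimated at 75000 nM, with a range from 35000 nM to 160000 nM.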

Compound 4, half-maximal cytotoxic concentration: > 100000 nM
Compound 4: a limit, no number; the forecaster's own chance of this, stated with the estimate: 25%; middle value at least 1.3-fold (0.12 log units) from the limit.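

In this assay compound 4 gives > 100000 nM, which is a limit of the assay and not a number. Read only as a floor, the step is an at least 1.4-fold higher number from compound 3 to compound 4 (0.14 log units; that floor lies within the scatter), so methyl in place of hydrogen on an aromatic carbon brought no measured fall in the number on this core, just as it brought none on the core of compound 1. This does not show that the change has the same size on both cores, because the second step has a floor but no measured size: the same change on two cores in this assay, a 1.1-fold higher number (0.04 log units; within the scatter) from compound 1 to compound 2 and an at least 1.4-fold higher number (0.14 log units; that floor lies within the scatter) from compound 3 to compound 4; the limit leaves it open whether they differ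

The compounds shown leave open how a longer chain such as ethyl, or a halogen such as fluorine, would read at this place on either core in this assay. They also leave open whether the methyl step would read the same with a carboxylic acid in place of the ethoxycarbonyl group of compound 3.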